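A few compounds are considered here, and "the series" means these few. Any claim that something is new, unique, unknown or untested is made for them only; others in the source may bear on it.

Measured so far in a physicochemical assay for lipophilicity, at pH 7.4; a higher number here means a more lipophilic compound, a lower number a more polar compound
- compound 1 `CNC(=O)c1cc(C(=O)NC2CC2)cc2c1OC[C@H]2c1cccc2[nH]ccc12` gives 3.5
- compound 2 `CNC(=O)c1cc(C(=O)N[C@H]2[C@@H]3COC[C@@H]32)cc2c1OC[C@H]2c1cccc(OC)c1` gives 3.2

Compound 2 (3.2) lies within the scatter of compound 1 (3.5), so the two values set no order. For the measured compounds named here, no measured pair differs in one place only, which leaves no measured step to carry over.

Compound 3 `CNC(=O)c1cc(C(=O)NC2CC2)cc2c1OC[C@H]2c1cccc(OC)c1` has not yet been measured. It differs from compound 2 by a single change (a group of 3 heavy atoms (3 carbon; one three-membered non-aromatic ring of carbon only) in place of a group of 6 heavy atoms (5 carbon, 1 oxygen; one three-membered non-aromatic ring of carbon only, one five-membered non-aromatic ring with 1 hetero atom), on an amide-type nitrogen). The group that leaves has one five-membered non-aromatic ring with 1 hetero atom and 1 hydrogen-bond acceptor, and cyclopropyl has 0 hydrogen-bond acceptors.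

Starting from compound 2 (3.2), the expectation rests on this structural change alone and is therefore loose. A modest rise is expected, estimated as a number 0.30 log units higher from compound 2 to compound 3 (within the scatter) in this assay and of a size that may not clear the scatter. The estimate for compound 3 is 3.5 (expected range 3.1 to 3.9).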

Compound 3, distribution coefficient: 3.8
For compound 3 the middle estimate is 0.30 log units below the measured one; measured number inside the range.
By their numbers in this assay, from the lowest: compounds 2, 1 and 3 (each within the scatter of the next, the first and the last beyond it).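

In this assay, cyclopropyl in place of the group carrying the five-membered non-aromatic ring with 1 hetero atom, on the amide-type nitrogen, gives a number 0.60 log units higher from compound 2 to compound 3 (beyond the scatter). For the compounds shown here, this is the first step read at this position, and it shows that the change can clear the scatter with 3-methoxyphenyl held constant on the saturated ring carbon. At that carbon, 3-methoxyphenyl in place of 1H-indol-4-yl gives a number 0.30 log units higher from compound 1 to compound 3 (within the scatter), so with cyclopropyl on the nitrogen this pair is not separated in this assay, and no measurement shown gives a reason for either step.

From the compounds shown here alone, the step at the nitrogen rests on a single pair, so whether it carries over to compounds with 1H-indol-4-yl on the saturated ring carbon stays open. Also open, going by these compounds, is whether the oxygen or the size of the leaving group accounts for the step, a question that a carbon-only group such as cyclopentyl on the amide-type nitrogen would bear on in this assay.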